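Cyano to Ethynyl on the Chain Nitrogen Substituent

A few compounds are considered here, and "the series" means these few. Any claim that something is new, unique, unknown or untested is made for them only; others in the source may bear on it.

The measured compounds: compound 1 `CCN(Cc1ccc2nc(C)[nH]c(=O)c2c1)c1ccc(C(=O)N[C@@H](CCC(=O)O)C(=O)O)c(C)c1` with 320 nM; compound 2 `Cc1nc2ccc(CN(CC#N)c3ccc(C(=O)N[C@@H](CCC(=O)O)C(=O)O)c(F)c3)cc2c(=O)[nH]1` with 170 nM; compound 3 `Cc1nc2ccc(CNc3ccc(C(=O)N[C@@H](CCC(=O)O)C(=O)O)cc3F)cc2c(=O)[nH]1` with 9340 nM.

In an assay on isolated protein for inhibition of Thymidylate synthase (Mus musculus) (on this read-out lower numbers stand for stronger inhibition and higher numbers for weaker inhibition), compound 2 gives the lowest of the three numbers. Compound 1 lies nearest to it, and the gap between the two falls within the usual scatter of repeated measurements, so no order between compound 1 and compound 2 can be read from these values. Compound 3 stands furthest away, with a number well beyond the scatter, so compound 3 inhibits clearly more weakly than compound 2.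

Compound 4 `C#CCN(Cc1ccc2nc(C)[nH]c(=O)c2c1)c1ccc(C(=O)N[C@@H](CCC(=O)O)C(=O)O)c(F)c1` has not been measured. It differs from compound 2 in one place: ethynyl in place of cyano on a saturated chain carbon bound to a nitrogen on an aromatic ring. Within the data shown here, no pair of measured compounds shows this change, so nothing measured here tells its size or direction. The author expects a small step, if any, in this assay, not clearly beyond the scatter; the estimated step of a 1.5-fold lower number from compound 2 to compound 4 (0.19 log units; within the scatter) leans slightly toward stronger inhibition. Compound 4 is therefore estimated at 110 nM, within a range from 40 nM to 300 nM.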

Compound 4, half-maximal inhibitory concentration: 20 nM
Estimate against measurement, compound 4: 5.5-fold (0.74 log units) above, outside the stated range (below it).
By their numbers in this assay, from the lowest: compound 4; then compounds 2 and 1 (each within the scatter of the next); then compound 3.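

The exchange of cyano for ethynyl on a saturated chain carbon bound to a nitrogen on an aromatic ring is not a neutral swap in this assay because an 8.5-fold lower number from compound 2 to compound 4 (0.93 log units; beyond the scatter) is a step of modest size that stands beyond the scatter. Among these compounds, the earlier compounds held no pair differing in one place, so this is the first sign that the group on this chain responds to a single change, even though both groups count the same heavy atoms and one triple bond outside aromatic rings. Ethynyl lacks the hydrogen-bond acceptor counted for cyano, but nothing measured here explains the step.

The compounds shown leave open how an amine, a carboxylic acid or a longer chain on this nitrogen would compare with propargyl. They also leave open whether cyanomethyl to propargyl gives a similar step when the rest of the molecule differs from compound 2.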